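The source may hold more compounds than are shown below. What is called first, only, known or untested is meant among the compounds shown, and "the series" means these compounds.

Three compounds that share one core and differ only in the group on the outer aromatic ring have been measured. In an assay on isolated protein for inhibition of protein deacetylase HDAC6 (Homo sapiens) (on this read-out higher numbers stand for weaker inhibition and lower numbers for stronger inhibition), compound 1 `O=C(NO)c1ccc(Cn2ccc3cc(C(=O)c4ccc(F)cc4)ccc32)cc1` gives 9.25 nM. Compound 2 `COc1ccc(C(=O)c2ccc3c(ccn3Cc3ccc(C(=O)NO)cc3)c2)cc1` carries methoxy where compound 1 carries fluoro. In this assay compound 2 gives 3.92 nM. Compound 3 `O=C(NO)c1ccc(Cn2ccc3cc(C(=O)c4ccc(Cl)cc4)ccc32)cc1`, with chloro at that aromatic carbon, gives 6.73 nM in this assay. The separation of compound 3 from each of the others is small: there is a 1.4-fold lower number from compound 1 to compound 3 (0.14 log units; within the scatter), and a 1.7-fold higher number from compound 2 to compound 3 (0.23 log units; within the scatter). Among the measured compounds shown here, the only pair separated beyond the scatter is a 2.4-fold lower number from compound 1 to compound 2 (0.37 log units; beyond the scatter), and even that step is modest.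

Compound 4 `Cc1ccc(C(=O)c2ccc3c(ccn3Cc3ccc(C(=O)NO)cc3)c2)cc1` differs from compound 3 by methyl in place of chloro on an aromatic carbon. The measured steps that bear on this change are the three swaps already made at the same aromatic carbon: a 1.4-fold lower number from compound 1 to compound 3 (0.14 log units; within the scatter), a 1.7-fold higher number from compound 2 to compound 3 (0.23 log units; within the scatter) and a 2.4-fold lower number from compound 1 to compound 2 (0.37 log units; beyond the scatter). Fluoro, chloro and methoxy all land within a narrow band of numbers in this assay, so for methyl the expectation is a step of no more than the scatter, in no particular direction. Compound 4 is therefore estimated at 6 nM, with a likely range from 3 nM to 12 nM. That estimate corresponds to a 1.1-fold lower number from compound 3 to compound 4 (0.05 log units; within the scatter), which is expected to stay within the scatter.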

Compound 4, half-maximal inhibitory concentration: 11.9 nM
The estimate for compound 4 lay 2.0-fold (0.30 log units) below the measured number, and the stated range covers the measured number.
By their numbers in this assay, from the lowest: compounds 2, 3, 1 and 4 (each within the scatter of the next, the first and the last beyond it).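

In this assay, methyl in place of chloro gives a 1.8-fold higher number from compound 3 to compound 4 (0.25 log units; within the scatter) and methyl in place of fluoro gives a 1.3-fold higher number from compound 1 to compound 4 (0.11 log units; within the scatter), so neither swap separates methyl from these two halogens on this aromatic carbon, para to a large group. Methyl in place of methoxy gives a 3.0-fold higher number from compound 2 to compound 4 (0.48 log units; beyond the scatter), the widest gap yet seen at this carbon, although still a modest one; it suggests that swapping between these two groups matters more here than swapping methyl for a halogen, while compound 3 , with chloro, stays within the scatter of both compound 2 and compound 4 . No supporting information is available to explain the gap between methoxy and methyl.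

All four groups are small, and so the compounds shown leave open whether this carbon would accept much larger changes with the same narrow spread of numbers. An amine, a carboxylic acid or a longer chain such as butoxy at this carbon could stay within that band or move well outside it, and the compounds here give no way of telling which.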